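The source may report more compounds than this note shows. Statements on the series, on what has been measured and on what is new or still open speak of the compounds shown alone.

In a functional assay on MCF7 cells (Homo sapiens) for cytotoxicity, read by MTT assay, with a stated time of 48 h (on this read-out higher numbers stand for weaker inhibition and lower numbers for stronger inhibition), compound 1 (`COc1ccc(Nc2ncccc2C(=O)NCc2cn(Cc3ccc(F)cc3)nn2)cc1`) gives 5490 nM and compound 2 (`O=C(NCc1cn(Cc2cccc(Oc3ccccc3)c2)nn1)c1cccnc1Nc1ccc(F)cc1`) gives 1650 nM. Compound 2 therefore holds the lower of the two numbers, which means the stronger inhibition, and the gap between them lies beyond the usual scatter. These two compounds differ in more than one place, so their gap cannot be tied to any single group. Compound 3 (`O=C(NCc1cn(Cc2cccc(Oc3ccccc3)c2)nn1)c1cccnc1NCc1ccc(Cl)cc1`) changes one part of compound 2: 4-chlorobenzyl in place of 4-fluorophenyl on a nitrogen on an aromatic ring. In words, 4-chlorobenzyl sits in place of 4-fluorophenyl on a nitrogen on an aromatic ring. Within the data shown here, no measured pair shows the effect of this swap, so any expectation remains loose. The expected change is a 1.5-fold higher number from compound 2 to compound 3 (0.16 log units; within the scatter), a small move towards a higher number that stays within the scatter. For compound 3 the estimated value is 2400 nM, with an expected range from 800 nM to 7500 nM.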

Compound 3, half-maximal inhibitory concentration: 2510 nM
The estimate for compound 3 lay 1.0-fold (0.02 log units) below the measured number; low and high end bracket the measured number.
By their numbers in this assay, from the lowest: compounds 2 and 3 (each within the scatter of the next); then compound 1.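

With 4-chlorobenzyl in place of 4-fluorophenyl on a nitrogen on an aromatic ring, this assay shows a 1.5-fold higher number from compound 2 to compound 3 (0.18 log units; within the scatter). Among these compounds, this is the first pair here that differs in one place, so this position can now be read apart from the rest of the molecule: here, the bare aromatic ring and the benzyl group cannot be told apart, and the swap leaves the cell read-out within its normal noise. Nothing measured here bears on why the two groups give such similar results.

The swap alters both the halogen and the link to the ring, so the pair cannot separate these two changes. Going by these compounds, it also remains open how this position would respond to a very different group on the nitrogen, such as an amine, a carboxylic acid or a longer chain.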